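Replacing methyl with dimethylamino in compound 3

The source may report more compounds than this note shows. Statements on the series, on what has been measured and on what is new or still open speak of the compounds shown alone.

Measured so far:
Compound 1 (`CCCCCCCCCCCCCCCC(NCc1ccccc1O)=C1C(=O)OC(CO)C1=O`) gives 2440 nM
Compound 2 (`CCCCCCCCCCCCCCCC(NCc1cccc(Cl)c1)=C1C(=O)OC(CO)C1=O`) gives 12000 nM
Compound 3 (`CCCCCCCCCCCCCCCC(NCc1ccc(C)cc1)=C1C(=O)OC(CO)C1=O`) gives 19100 nM

In a functional assay on HL-60 cells (Homo sapiens) for inhibition, read by resazurin assay, with a stated time of 48 h (a higher number here means a weaker inhibitor, a lower number a stronger inhibitor), compound 3 stands at 19100 nM and cannot be told apart from its nearest neighbour, since the measured step is a 1.6-fold higher number from compound 2 to compound 3 (0.20 log units; within the scatter). The clear gaps in this small set are a 7.8-fold higher number from compound 1 to compound 3 (0.89 log units; beyond the scatter) and a 4.9-fold higher number from compound 1 to compound 2 (0.69 log units; beyond the scatter).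

Compound 4 (`CCCCCCCCCCCCCCCC(NCc1ccc(N(C)C)cc1)=C1C(=O)OC(CO)C1=O`) keeps everything in compound 3 except one group, with dimethylamino in place of methyl on an aromatic carbon.

Within the data shown here, no measured compound carries dimethylamino, so the data offer no direct guide. The two larger steps both start from the 2-hydroxyphenyl group of compound 1, which compound 3 and compound 4 lack. The closer precedent is therefore a 1.6-fold higher number from compound 2 to compound 3 (0.20 log units; within the scatter), a swap that stayed small. No change beyond the scatter is expected, and the expected step is a 1.3-fold lower number from compound 3 to compound 4 (0.10 log units; within the scatter) in this assay. Compound 4 is estimated at 15000 nM, with an expected range from 6000 nM to 40000 nM.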

Compound 4, half-maximal inhibitory concentration: 10900 nM
Compound 4: middle estimate off by 1.4-fold (0.14 log units), on the high side; measured number inside the range.
By their numbers in this assay, from the lowest: compound 1; then compounds 4, 2 and 3 (each within the scatter of the next).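

In this assay, this position on the aromatic ring, para to a large group, accepts dimethylamino with its three heavy atoms and one hydrogen-bond acceptor in place of the single carbon of methyl, with no change that can be told from scatter: a 1.8-fold lower number from compound 3 to compound 4 (0.24 log units; within the scatter). The 3-chlorophenyl and 4-(dimethylamino)phenyl groups also cannot be told apart, a 1.1-fold lower number from compound 2 to compound 4 (0.04 log units; within the scatter), while the 2-hydroxyphenyl group still stands clear of the new compound, a 4.5-fold higher number from compound 1 to compound 4 (0.65 log units; beyond the scatter). No supporting measurement bears on why these steps have these sizes.

On these data alone, whether this position ever responds remains open, and a carboxylic acid or a morpholine ring there would test it more sharply. As far as these compounds go, it is also open whether the gap seen with 2-hydroxyphenyl would persist on a shorter chain.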